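Lengthening an alkoxy chain on a chlorophenyl biguanide-like core

A few compounds are considered here, and "the series" means these few. Any claim that something is new, unique, unknown or untested is made for them only; others in the source may bear on it.

Compound 3 `CCCCOC(=N)NC(=N)Nc1ccc(Cl)cc1` stands highest of the three numbers measured in a physicochemical assay for lipophilicity, in phosphate buffer, measured as octanol-water partition, at pH 11.5 (a lower number here means a more polar compound, a higher number a more lipophilic compound), giving 3.32. Compound 2 `CCNC(=N)NC(=N)Nc1ccc(Cl)cc1` gives 2.14 and compound 1 `CNC(=N)NC(=N)Nc1ccc(Cl)cc1` gives 1.58. Compound 4 `CCCCCCCCOC(=N)NC(=N)Nc1ccc(Cl)cc1` differs from compound 3 by butyl in place of hydrogen on a saturated chain carbon, four bonds along the chain from an oxygen on an unsaturated carbon. For the measured compounds named here, no measured step adds carbon to an alkoxy chain; the nearest comparison is a number 0.56 log units higher from compound 1 to compound 2 (beyond the scatter), a modest rise for one added carbon on nitrogen. Four added carbons should therefore give a large rise in this assay. For compound 4 the expected step is a number 1.78 log units higher from compound 3 to compound 4 (beyond the scatter). Compound 4 is estimated at 5.1, in the range 4.4 to 5.8.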

Compound 4, partition coefficient: 5.32
Compound 4: the middle estimate sits 0.22 log units below what was measured; the range from low to high includes it.
By their numbers in this assay, from the lowest: compound 1; then compound 2; then compound 3; then compound 4.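

Butyl in place of hydrogen on the alkoxy chain gives a number 2.00 log units higher from compound 3 to compound 4 (beyond the scatter) in this assay and is the first measured step that extends this chain itself. The earlier steps shown here extended a chain on nitrogen or exchanged an amino group for butoxy, so compound 4 shows that this position also responds to added carbon. No measured evidence explains the size of this step.

As far as these compounds go, whether a longer chain would raise the number further remains open, as does the effect of an amine or a carboxylic acid at the chain end in this assay on this shared core.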